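Urea series: chain saturation and aryl substitution notes

The source may hold more compounds than are shown below. What is called first, only, known or untested is meant among the compounds shown, and "the series" means these compounds.

Compound 1 `CCCCCCCC/C=C\CCCCCCCCNC(=O)Nc1ccc(F)cc1F` gives 4700 nM in an assay on microsomes from intestinal mucosa for inhibition of acyl-CoA:cholesterol acyltransferase (Oryctolagus cuniculus); a lower number here means a stronger inhibitor, a higher number a weaker inhibitor. Compound 3 `CCCCCCCCCCCCCCNC(=O)Nc1ccc(F)cc1F` differs from it by hexyl in place of dec-1-en-1-yl on a saturated chain carbon, eight bonds along the chain from an amide-type nitrogen and in this assay compound 3 gives 340 nM; the step is a 14-fold lower number from compound 1 to compound 3 (1.14 log units; beyond the scatter). Compound 2 `CCCCCCCC/C=C\CCCCCCCCNC(=O)Nc1c(CC)cccc1C(C)C` carries the other core, differing from compound 1 by 2-ethyl-6-isopropylphenyl in place of 2,4-difluorophenyl on an amide-type nitrogen; in this assay compound 2 gives 37 nM, and the step is a 130-fold lower number from compound 1 to compound 2 (2.10 log units; beyond the scatter). Among the compounds with values here, compound 2 has the lowest number of the three measured so far, with both of its steps to the others beyond the scatter.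

Compound 4 `CCCCCCCCCCCCCCNC(=O)Nc1c(CC)cccc1C(C)C` is not yet measured. It differs from compound 2 by hexyl in place of dec-1-en-1-yl on a saturated chain carbon, eight bonds along the chain from an amide-type nitrogen, the same change as from compound 1 to compound 3, occurring twice among these compounds and at the same place both times. The step to compound 4 is expected to be a 6.2-fold lower number from compound 2 to compound 4 (0.79 log units; beyond the scatter). Within the data shown here, it stands beside a 14-fold lower number from compound 1 to compound 3 (1.14 log units; beyond the scatter), the only measured instance of this change, and whether the change carries over to the core of compound 2 is untested. Because compound 2 already stands at 37 nM, the expected step is taken somewhat smaller than the measured one. Compound 4 is thus expected to give about 6 nM, estimated between 1.5 nM and 25 nM, in this assay.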

Compound 4, half-maximal inhibitory concentration: 18 nM
For compound 4 the middle estimate is 3.0-fold (0.48 log units) below the measured one, within the range that was stated.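

Exchanging dec-1-en-1-yl for hexyl gives a lower number on both cores in this assay, but the size of the step does not carry from one core to the other: the same change on two cores in this assay, a 14-fold lower number (1.14 log units; beyond the scatter) from compound 1 to compound 3 and a 2.1-fold lower number (0.31 log units; beyond the scatter) from compound 2 to compound 4, 6.7-fold (0.83 log units) apart, beyond the scatter of two such steps

On the core of compound 2 the measured step is a 2.1-fold lower number from compound 2 to compound 4 (0.31 log units; beyond the scatter) and remains beyond the scatter, so the direction seen with the 2,4-difluorophenyl pair recurs with the 2-ethyl-6-isopropylphenyl pair, at a much smaller size. These two pairs show that a step measured on one core gave the direction but not the size on the other; they do not show why the sizes differ, nor whether the direction would hold on a third core.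

Still open, on these data alone, is how the step behaves when a longer saturated chain takes the place of hexyl, or when the aryl group carries an amine or a carboxylic acid. Also open, as far as these compounds go, is whether the gap between the two steps appears in any read-out other than this assay at all.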